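The source may report more compounds than this note shows. Statements on the series, on what has been measured and on what is new or still open speak of the compounds shown alone.

Compound 1 `O=C(O)c1ccc(C(=O)/C(=C\c2ccc(Br)c([N+](=O)[O-])c2)SCc2ccc(Br)cc2)cc1`: 1000 nM
Compound 2 `O=C(/C(=C\c1ccc(I)cc1)Sc1ccc(Br)cc1)c1ccc(Br)cc1`: 1000 nM
Compound 3 `O=C(O)c1ccc(C(=O)/C(=C\c2ccc(Br)c([N+](=O)[O-])c2)SCc2ccccc2Cl)cc1`: 1000 nM

In a functional assay on DU-145 cells (Homo sapiens) for inhibition, read by trypan blue exclusion, with a stated time of 96 h (on this read-out lower numbers stand for stronger inhibition of growth and higher numbers for weaker inhibition of growth), compound 1 gives 1000 nM and sits level with compound 2 and compound 3, all three within the scatter of one another. Compound 4 `COc1cc(/C=C(/SCc2ccc(Br)cc2)C(=O)c2ccc(C(=O)O)cc2)ccc1F` carries the change (4-fluoro-3-methoxyphenyl in place of 4-bromo-3-nitrophenyl on a double-bonded chain carbon bound to a double-bonded chain carbon). For the measured compounds named here, the only measured step, no change at the digits printed from compound 1 to compound 3 (within the scatter), alters the group on a saturated chain carbon bound to a sulfur, a different place, and shows no change. Compound 2 differs from compound 1 in several places at once, and its value is within the scatter of compound 1. Going by the values given here, no measured step touches the group on the double-bonded chain carbon, so no step beyond the scatter is expected. Compound 4 is therefore estimated at 1000 nM, between 400 nM and 2500 nM, an expected step of no change at the digits printed from compound 1 to compound 4 (within the scatter).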

Compound 4, concentration for 50% growth inhibition: 1000 nM
Compound 4: middle estimate and measured number agree at the digits printed, within the range that was stated.
By their numbers in this assay, from the lowest: compounds 1, 2, 3 and 4 (each within the scatter of the next).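

In this assay, for the compounds shown here, replacing 4-bromo-3-nitrophenyl with 4-fluoro-3-methoxyphenyl on a double-bonded chain carbon bound to a double-bonded chain carbon gives no change at the digits printed from compound 1 to compound 4 (within the scatter) at a place that no earlier single step had touched. This place therefore accepts a ring without the nitro group or the bromine, and the value stays level with that of compound 1. No evidence is available to explain this result.

The compounds shown do not reveal how the fluorine and the methoxy group each contribute on their own. On these data alone, what an amine or a second carboxylic acid on this ring, or a longer chain in its place, would do also remains open.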